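This account rests on a few compounds, and the source may have more. Where it says the series, first, only, none or still open, it means among the compounds named here.

Compound 1 `COc1ccc(-c2nc3sc(-c4ccccc4)cn3n2)cc1` gives 60%
Compound 2 `C/C(=N/O)c1ccc(NC(=O)Cn2nc(C(F)(F)F)nc2N)cc1` gives 8.65%
Compound 3 `COc1cc(-c2nc3sc(-c4ccccc4)cn3n2)cc(OC)c1OC` gives 40%

In a functional assay on HCT-116 cells (Homo sapiens) for inhibition, read by sulforhodamine B assay, with a stated time of 48 h, tested at 10 uM (a higher number here means more inhibition of growth at the concentration tested, a lower number less inhibition of growth), compound 1 gives the highest of these three numbers (60%). Compound 3 comes next (40%) and compound 2 comes last (8.65%). Both gaps to compound 1 lie beyond the usual scatter.

Compound 4 `COc1ccc(-c2nc3sc(-c4ccc(Cl)cc4)cn3n2)cc1` keeps the core of compound 1 and changes one place, phenyl to 4-chlorophenyl: chloro in place of hydrogen on an aromatic carbon. Among the measured compounds shown here, no measured pair here shows what such a swap does, so the expectation rests on compound 1 alone (60%). No step beyond the scatter is expected in either direction, and the estimated change is small (a number 2 percentage points higher from compound 1 to compound 4 (within the scatter)). For the measured compounds named here, with only three measured compounds, the range has to stay wide. The expected value for compound 4 is 62% (estimated range 40% to 82%).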

Compound 4, percent growth inhibition at one concentration: -16%
Compound 4: the middle estimate sits 78 percentage points above what was measured; the measured number lies below the stated range.
By their numbers in this assay, from the lowest: compound 4; then compound 2; then compound 3; then compound 1.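

In this assay, the place on the phenyl group para to a large group proves far from indifferent: putting chloro in place of hydrogen there gives a number 76 percentage points lower from compound 1 to compound 4 (beyond the scatter) in a single change. Among the compounds shown here, until now, no two compounds differed in only one place, so this is the first direct reading of a single change on the shared core, and it shows that one added heavy atom is enough to remove the growth inhibition seen with compound 1. Nothing at hand explains this step.

From the compounds shown here alone, it remains open whether the loss belongs to chloro in particular or would also follow from another group at this place, such as fluoro, an amine or a carboxylic acid. Going by these compounds, whether the same swap would act alike on compound 3 also remains open.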